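Chloro step from compound 2 to compound 3

The source may report more compounds than this note shows. Statements on the series, on what has been measured and on what is new or still open speak of the compounds shown alone.

Measured in a functional assay on NCI-H460 cells (Homo sapiens) for inhibition, read by sulforhodamine B assay, with a stated time of 48 h (a lower number here means a stronger inhibitor of growth, a higher number a weaker inhibitor of growth), so far:
- compound 1 `CCOC(=O)c1nn(-c2ccccc2)c(-c2ccccc2)c1CNC(C)(C)C` gives 76900 nM; 195000 nM (2 entries)
- compound 2 `CC(C)(C)NCc1c(C(=O)O)nn(-c2ccccc2)c1-c1ccccc1` gives > 716000 nM as a limit

Compound 2 has no single number, and its > 716000 nM is a limit of this assay only.

Compound 3 `CC(C)(C)NCc1c(C(=O)O)nn(-c2ccc(Cl)cc2)c1-c1ccccc1` differs from compound 2 by chloro in place of hydrogen on an aromatic carbon, with chloro in place of hydrogen on an aromatic carbon, para to a large group. For the measured compounds named here, no measured step covers this change, and no step beyond the scatter is expected in this assay. The expected move is an at least 1.4-fold lower number from compound 2 to compound 3 (0.15 log units; that floor lies within the scatter) for now. Compound 3 is estimated at 500000 nM, within a range of 150000 nM to 1000000 nM, and it may again read only as a limit.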

Compound 3, concentration for 50% growth inhibition: > 652000 nM
Compound 3: no number, only a limit; the forecaster's own chance of this, stated with the estimate: 55%; middle value at least 1.3-fold (0.11 log units) away from the limit.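

In this assay compound 3 reads only as a limit, > 652000 nM. Compound 2 is likewise a limit, > 716000 nM, so no step can be read between these two compounds. From the compounds shown here alone, whether phenyl to 4-chlorophenyl changes growth inhibition at all remains open.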